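The compounds below may be only part of what the source reports. "The series", "measured", "known", "first", "only" and "open" are said of these compounds alone.

Compound 1, `CCCSc1nc(Cl)c2c(n1)N(Cc1ccccc1)C(C(=O)N1CCN(C(=O)OC(C)(C)C)CC1)N2`: in a functional assay on TE-1 cells (Homo sapiens) for antiproliferative activity, read by MTT assay, with a stated time of 72 h (a higher number here means a weaker inhibitor, a lower number a stronger inhibitor), compound 1 gives 31200 nM.
Compound 2, `CCCSc1nc(Cl)c2c(n1)N(Cc1cccs1)C(C(=O)N1CCN(C)CC1)N2`: in this assay compound 2 gives 39400 nM.
Compound 3, `CCCSc1nc(Cl)c2c(n1)N(Cc1ccccc1)C(C(=O)NCCNC(=O)OC(C)(C)C)N2`: in this assay compound 3 gives only a limit, > 64000 nM.

Compound 3 stands at the limit of this assay, (the limit of > 64000 nM in this assay, at which 1 of the 3 values shown sits), so its true value is not known as a number. For the measured compounds named here, compound 1 and compound 2 do give numbers, and both are weak inhibitors in this assay; no single-point step between any two of the measured compounds is available, so how much the amide substituent alone moves the read-out cannot be read from the data.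

Compound 4, `CCCSc1nc(Cl)c2c(n1)N(Cc1ccccc1)C(C(=O)Nc1ccccc1)N2`, keeps the shared core of compound 3 and differs from it in one place: phenyl in place of 2-((tert-butoxycarbonyl)amino)ethyl on an amide-type nitrogen. Without a measured step to lean on, the account expects compound 4 to remain in the same weak region as compound 1 and compound 2, with any shift from compound 3 likely small and possibly within the scatter. The estimated step from compound 3 to compound 4 in this assay is an at least 1.4-fold lower number from compound 3 to compound 4 (0.15 log units; that floor lies within the scatter). Compound 4 is therefore estimated at 45000 nM, within a range of 15000 nM to 90000 nM.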

Compound 4, half-maximal inhibitory concentration: > 64000 nM
Compound 4: no number, only a limit; the forecaster's own chance of this, stated with the estimate: 40%; middle value at least 1.4-fold (0.15 log units) away from the limit.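

For the compounds shown here, compound 3 and compound 4 both give only a limit in this assay, so no step between them can be read: the limit of > 64000 nM in this assay, at which 2 of the 4 values shown sit. The compounds shown leave open how far a change of the substituent on the amide-type nitrogen alone moves the read-out, and whether either compound has any measurable activity in this cell line.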